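The source may hold more compounds than are shown below. What is called first, only, known or untested is meant among the compounds shown, and "the series" means these compounds.

Compound 2 `Cc1nc(Nc2ccccc2)sc1C(=O)/C=C/c1ccccc1` and compound 1 `Cc1cccc(Nc2nc(C)c(C(=O)/C=C/c3ccccc3)s2)c1` are related by methyl in place of hydrogen on an aromatic carbon. In a functional assay on Bel-7402 cells (Homo sapiens) for cytotoxicity, read by MTT assay (a lower number here means a stronger inhibitor, a higher number a weaker inhibitor), compound 2 gives > 25000 nM, which is a limit of the assay and not a number. Compound 1 likewise reaches only a limit in this assay, > 25000 nM. The step that the two limits leave unreadable from compound 2 to compound 1 therefore stays unreadable. Compound 3 `COc1cc(/C=C/C(=O)c2sc(Nc3ccccc3)nc2C)cc(OC)c1OC` carries a core whose difference from the core of compound 2 is not broken down here. In this assay compound 3 gives > 25000 nM, again a limit. Every value shown so far sits at the limit of > 25000 nM in this assay, at which 3 of the 3 values shown sit.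

Compound 4 `COc1cc(/C=C/C(=O)c2sc(Nc3ccc(C)cc3)nc2C)cc(OC)c1OC` has not yet been measured. It differs from compound 3 by methyl in place of hydrogen on an aromatic carbon. This is the same kind of change as that made from compound 2 to compound 1, but the place is not the same: there the methyl enters meta to a large group, here para to a large group. Within the data shown here, with all three measured values at the limit of > 25000 nM in this assay, at which 3 of the 3 values shown sit, the step from compound 3 to compound 4 is expected to be a step that the limit leaves unreadable from compound 3 to compound 4, because nothing measured so far rises from that limit. Compound 4 is accordingly estimated at 30000 nM, with a range from 8000 nM to 100000 nM, most likely reported once more only as a limit.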

Compound 4, half-maximal inhibitory concentration: > 25000 nM
Compound 4 gave a limit, no number; the forecaster's own chance of this, stated with the estimate: 80%; the middle value lies beyond the limit too.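

In this assay compound 4 gives > 25000 nM, which is a limit and not a number. Compound 3 also stands at a limit, so no step can be read between compound 3 and compound 4. The compounds shown leave open what any of their true values is and whether methyl in place of hydrogen changes them, with all results at one point: the limit of > 25000 nM in this assay, at which 4 of the 4 values shown sit.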